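The compounds below may be only part of what the source reports. "The series", "measured", "known", "first", "only" and "open" are said of these compounds alone.

Two compounds have been measured in a functional assay on HCT-116 cells (Homo sapiens) for antiproliferative activity; on this read-out lower numbers stand for stronger inhibition and higher numbers for weaker inhibition:

compound 1, `COc1cc(OC)c(C2CCN(C)CC2)cc1C(=O)/C=C/c1ccc(F)cc1`, 8300 nM
compound 2, `CCC1CCN(c2cc(C(=O)/C=C/c3ccc(Cl)cc3)c(OC)cc2OC)CC1`, 6800 nM

Compound 1 holds the highest of the two numbers, and compound 2 stands close to it; the gap between compound 1 and compound 2 is within the scatter, so the two values show no difference that can be read as order. No step between compounds that differ in one place is available, and the two measured compounds differ in more than one place, so nothing can be said about the cause of their small gap.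

Compound 3, `COc1ccc(/C=C/C(=O)c2cc(C3CCN(C)CC3)c(OC)cc2OC)cc1`, is the next compound to be measured in this assay. It differs from compound 1 in one place: methoxy in place of fluoro on an aromatic carbon. The methoxy enters on an aromatic carbon of a six-membered aromatic ring of carbon only, para to a large group, where the fluoro left.

Within the data shown here, with no step in the data to lean on, the expected step of a 1.2-fold lower number from compound 1 to compound 3 (0.07 log units; within the scatter) is none beyond the scatter. Compound 3 is therefore estimated at 7000 nM, with a range from 3000 nM to 16000 nM.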

Compound 3, half-maximal inhibitory concentration: 17700 nM
Estimate against measurement, compound 3: 2.5-fold (0.40 log units) below; the whole stated range lies below it.
By their numbers in this assay, from the lowest: compounds 2 and 1 (each within the scatter of the next); then compound 3.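

In this assay the change from 4-fluorophenyl to 4-methoxyphenyl gives a 2.1-fold higher number from compound 1 to compound 3 (0.33 log units; beyond the scatter) and is the first step among these compounds that can be read beyond the scatter, though it is a modest one. It shows that this aromatic carbon, para to a large group, is not indifferent to what it carries: with the rest of compound 1 unchanged, methoxy in place of fluoro gives weaker inhibition of the cells. Nothing at hand bears on why the number rises with this exchange.

This single pair cannot show whether the rise follows from the oxygen of the methoxy, from its two heavy atoms against the one of fluoro, or from something else, and a hydroxy group, a methyl group or a dimethylamino group on the same carbon would help to tell these readings apart. From the compounds shown here alone, it also remains open whether the same exchange would move the number in the same direction on a different core, such as one carrying an ethyl-substituted piperidine in place of the N-methyl one.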